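Benzyl on the ring amide nitrogen of compound 1

This account rests on a few compounds, and the source may have more. Where it says the series, first, only, none or still open, it means among the compounds named here.

For the measured compounds named here, in a functional assay on Caco-2 cells (Homo sapiens) for antiproliferative activity, read by MTT assay (on this read-out higher numbers stand for weaker inhibition and lower numbers for stronger inhibition), compound 1 (`NS(=O)(=O)c1ccc(/N=C2\NC(=O)/C(=C3/C(=O)Nc4ccc(Cl)cc43)S2)cc1`) gives 20300 nM and holds the lower of the two numbers so far, while compound 2 (`COc1ccc2c(c1)/C(=C1/S/C(=N/c3ccc(S(N)(=O)=O)cc3)NC1=O)C(=O)N2`) gives 98300 nM. Compound 3 (`NS(=O)(=O)c1ccc(/N=C2\NC(=O)/C(=C3/C(=O)N(Cc4ccccc4)c4ccc(Cl)cc43)S2)cc1`) carries benzyl in place of hydrogen on an amide-type nitrogen in a ring. Going by the values given here, the only measured step (a 4.8-fold higher number from compound 1 to compound 2 (0.69 log units; beyond the scatter)) lies at an aromatic carbon and bears on size only loosely, since no measured compound changes this nitrogen. The direction in this assay is therefore a weak guess, and the expected step is somewhat smaller (a 2.3-fold lower number from compound 1 to compound 3 (0.35 log units; beyond the scatter)). Compound 3 is estimated at 9000 nM, with an expected range of 2500 nM to 40000 nM.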

Compound 3, half-maximal inhibitory concentration: 13700 nM
For compound 3 the middle estimate is 1.5-fold (0.18 log units) below the measured one, and the stated range covers the measured number.
By their numbers in this assay, from the lowest: compounds 3 and 1 (each within the scatter of the next); then compound 2.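

In this assay benzyl in place of hydrogen on an amide-type nitrogen in a ring gives a 1.5-fold lower number from compound 1 to compound 3 (0.17 log units; within the scatter) and so this nitrogen, unchanged in the earlier pair, accepts a group of this size without a step beyond the scatter. The amide hydrogen is therefore not required for activity at this level in this pair. Nothing on hand explains this result. Still open, on these data alone, is whether methyl or a longer chain ending in an amine on this nitrogen gives a similar number, and whether benzyl gives the same outcome with methoxy in place of chloro.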